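The source may report more compounds than this note shows. Statements on the series, on what has been measured and on what is new or still open speak of the compounds shown alone.

Three compounds with a shared triazene core carry a phenol on one side and a substituted benzene ring on the other. Compound 1 `COC(=O)c1ccc(/N=N/N(C)C(=O)CCc2cccc(O)c2)cc1` gives 94.7 h in a physicochemical assay for metabolic stability, read by HPLC, in phosphate buffer, at pH 7.4; on this read-out higher numbers stand for a longer-lived compound and lower numbers for a shorter-lived compound. Compound 2 `CN(/N=N/c1ccc(C#N)cc1)C(=O)CCCCc1ccc(O)cc1`, which has a longer chain to the phenol and a cyano group on the far ring, gives 82.5 h in this assay. Compound 3 `CN(/N=N/c1ccc(C(N)=O)cc1)C(=O)CCc1ccc(O)cc1`, with the shorter chain and a carbamoyl group, gives 118 h in this assay. The three numbers lie within the usual scatter of one another, so none is separated from the rest; compound 2 sits at the low end of that narrow band.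

Compound 4 `CN(/N=N/c1ccc(C(N)=O)cc1)C(=O)CCCCc1ccc(O)cc1` keeps the longer chain of compound 2 and changes the far ring: carbamoyl in place of cyano on an aromatic carbon. Within the data shown here, no pair of measured compounds differs by exactly this change, so its effect on this assay is not known from the data. Compound 3 carries the same carbamoyl group on a shorter chain and gives 118 h, a number that does not stand apart from compound 2. The step from compound 2 to compound 4 is therefore expected to stay within the scatter, a 1.2-fold higher number from compound 2 to compound 4 (0.08 log units; within the scatter). Compound 4 is estimated to give 100 h in this assay, in a range from 60 h to 170 h.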

Compound 4, half-life: 182 h
Compound 4: middle estimate off by 1.8-fold (0.26 log units), on the low side; measured number outside the range, above it.
By their numbers in this assay, from the lowest: compounds 2, 1, 3 and 4 (each within the scatter of the next, the first and the last beyond it).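

On the far ring, at the aromatic carbon para to a large group, carbamoyl in place of cyano gives in this assay a 2.2-fold higher number from compound 2 to compound 4 (0.34 log units; beyond the scatter). Among these compounds, this is the first comparison where only one place differs, and the first step here that lies beyond the scatter. The earlier compounds shown here each differed in more than one place, so they could not show that this position alone can shift the half-life, though the shift is modest and rests on this single pair, on the longer chain.

The compounds shown leave open whether carbamoyl in place of cyano gives a similar step on the shorter chain, where compound 3 gives 118 h. They also leave open how other groups at this position, such as a carboxylic acid or an amine, would compare with cyano and carbamoyl in this assay. No measurement offered here accounts for the step between these two groups.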